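Solubility across the aryl substituent at the fused core

The source may report more compounds than this note shows. Statements on the series, on what has been measured and on what is new or still open speak of the compounds shown alone.

Measured so far in a physicochemical assay for solubility, read by HPLC, using the shake flask method, measured as kinetic solubility, with a stated time of 2 h, at pH 7.4; on this read-out lower numbers stand for lower solubility and higher numbers for higher solubility:
compound 1 `Cc1cc(NCc2ccccn2)n2ncc(-c3ccc(F)c(Cl)c3)c2n1` — < 5000 nM
compound 2 `Cc1cc(NCc2ccccn2)n2ncc(-c3ccco3)c2n1` — 48800 nM

The value of compound 1 is a limit of this assay, not a number (the limit of < 5000 nM in this assay, at which 1 of the 2 values shown sits). Compound 2 gives the only number shown, 48800 nM. Compound 3 `Cc1cc(NCc2ccccn2)n2ncc(-c3ccc(F)cc3C)c2n1` differs from compound 2 by 4-fluoro-2-methylphenyl in place of furan-2-yl on an aromatic carbon. Going by the values given here, the one measured step that bears on this change is an at least 9.7-fold higher number from compound 1 to compound 2 (0.98 log units; beyond the scatter); compound 3 carries an aromatic carbon-only ring as compound 1 does, so the reverse direction is expected, a drop of about a 9.8-fold lower number from compound 2 to compound 3 (0.99 log units; beyond the scatter), with a fair chance that only a limit is reported. Compound 3 is therefore estimated at 5000 nM, between 1500 nM and 20000 nM.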

Compound 3, solubility: 42300 nM
Compound 3: the middle estimate sits 8.5-fold (0.93 log units) below what was measured; the whole stated range lies below it.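

In this assay, a six-membered aromatic ring of carbon only at this position does not by itself go with a low read-out, since 4-fluoro-2-methylphenyl in place of furan-2-yl gives a 1.2-fold lower number from compound 2 to compound 3 (0.06 log units; within the scatter). The substitution on that ring matters more in this small set, with 4-fluoro-2-methylphenyl in place of 3-chloro-4-fluorophenyl giving an at least 8.4-fold higher number from compound 1 to compound 3 (0.92 log units; beyond the scatter). The value of compound 1 is a limit, not a number: the limit of < 5000 nM in this assay, at which 1 of the 3 values shown sits.

The compounds shown do not tell which difference between these two rings accounts for that step. On these data alone, how an amine or a carboxylic acid on this aromatic carbon would read also stays open.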